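Capping the Hydroxy Group on a Chemokine Receptor Binder

A few compounds are considered here, and "the series" means these few. Any claim that something is new, unique, unknown or untested is made for them only; others in the source may bear on it.

Compound 3 `Cc1ccccc1C(=O)Nc1ccc(S(=O)(=O)NC2CCN(C(=O)CO)CC2)c2ccccc12` gives 5.4 nM in an assay on L1.2 cells for binding affinity to C-C chemokine receptor type 8 (Homo sapiens) (a lower number here means a stronger inhibitor, a higher number a weaker inhibitor), the second highest of the three numbers measured. Its nearest neighbour is compound 2 `CC(=O)N1CCC(NS(=O)(=O)c2ccc(NC(=O)c3ccccc3C)c3ccccc23)CC1`, which gives 6.7 nM; the strongest measured inhibitor is compound 1 `CCC(=O)N1CCC(NS(=O)(=O)c2ccc(NC(=O)c3ccccc3C)c3ccccc23)CC1` with 2.5 nM. Compound 4 `COCC(=O)N1CCC(NS(=O)(=O)c2ccc(NC(=O)c3ccccc3C)c3ccccc23)CC1` differs from compound 3 by methyl in place of hydrogen on an oxygen on a saturated carbon. Among the compounds with values here, two measured steps touch this end of the chain: a 2.2-fold higher number from compound 1 to compound 3 (0.33 log units; beyond the scatter), and a 1.2-fold lower number from compound 2 to compound 3 (0.09 log units; within the scatter). Hydroxy and hydrogen thus give numbers within the scatter of each other, while compound 1, carrying methyl where compound 3 carries hydroxy, gives the strongest value. The added methyl in compound 4 is therefore expected to give a step of a 1.4-fold lower number from compound 3 to compound 4 (0.13 log units; within the scatter) in this assay, within the scatter. Compound 4 is estimated at 4 nM, between 1.5 nM and 11 nM.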

Compound 4, inhibition constant: 15.8 nM
Beside the measured number, compound 4's estimate is 4.0-fold (0.60 log units) below it; the measured number lies above the stated range.
By their numbers in this assay, from the lowest: compound 1; then compounds 3 and 2 (each within the scatter of the next); then compound 4.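

In this assay, capping the hydroxy group as methoxy is not a neutral change: adding this one methyl on the oxygen gives a step beyond the scatter (a 2.9-fold higher number from compound 3 to compound 4 (0.47 log units; beyond the scatter)). Methoxy on this saturated chain carbon also gives a higher number than hydrogen (a 2.4-fold higher number from compound 2 to compound 4 (0.37 log units; beyond the scatter)) or methyl (a 6.3-fold higher number from compound 1 to compound 4 (0.80 log units; beyond the scatter)), so compound 4 is the weakest inhibitor of the four. No measured evidence explains these steps. Going by these compounds, it remains open whether ethoxy would raise the number further, and whether an amine or a carboxylic acid here would behave more like hydroxy or methoxy.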